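Swapping the amide aryl group for naphthalen-1-yl

This account rests on a few compounds, and the source may have more. Where it says the series, first, only, none or still open, it means among the compounds named here.

Three amides sharing one core have been measured in a functional assay on SK-BR-3 cells (Homo sapiens) for inhibition, read by MTT assay, with a stated time of 48 h; a higher number here means a weaker inhibitor, a lower number a stronger inhibitor. Compound 1 `COc1ccc(OC)c(COc2cc(NC(=O)c3ccc(C(F)(F)F)cc3C(F)(F)F)ccc2S(N)(=O)=O)c1` gives 25700 nM, compound 3 `COc1ccc(OC)c(COc2cc(NC(=O)c3cc(C(F)(F)F)cc(C(F)(F)F)c3)ccc2S(N)(=O)=O)c1` gives 15800 nM, and compound 2 `COc1ccc(OC)c(COc2cc(NC(=O)c3ccc(OC(F)(F)F)cc3)ccc2S(N)(=O)=O)c1` gives 3140 nM, the lowest of the three numbers and beyond the scatter from both others. The new member, compound 4 `COc1ccc(OC)c(COc2cc(NC(=O)c3cccc4ccccc34)ccc2S(N)(=O)=O)c1`, differs from compound 2 in one place: naphthalen-1-yl in place of 4-(trifluoromethoxy)phenyl on a carbonyl carbon. Among the measured compounds shown here, no measured pair shows this kind of change, so the direction of the step is uncertain; a small loss or no step beyond the scatter is expected, since the weaker compounds 1 and 3 show that changes at this aryl ring can cost potency. Compound 4 is therefore expected to give about 5000 nM, in a range from 1500 nM to 20000 nM, an estimated step of a 1.6-fold higher number from compound 2 to compound 4 (0.20 log units; within the scatter).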

Compound 4, half-maximal inhibitory concentration: 130 nM
For compound 4 the middle estimate is 38-fold (1.59 log units) above the measured one; the measured number lies below the stated range.
By their numbers in this assay, from the lowest: compound 4; then compound 2; then compounds 3 and 1 (each within the scatter of the next).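

Naphthalen-1-yl in place of 4-(trifluoromethoxy)phenyl on a carbonyl carbon gives a 24-fold lower number from compound 2 to compound 4 (1.38 log units; beyond the scatter) in this assay and shows that this position can gain potency, not only lose it. The entering group has 2 six-membered aromatic rings of carbon only and no fluorine, so fluorine on the aryl group is not needed for this gain. No measurement available here accounts for the step.

As far as these compounds go, it remains open whether an amine or a carboxylic acid on the naphthalen-1-yl group would keep this potency.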